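Efficacy of a pair with a changed aryl substituent

A few compounds are considered here, and "the series" means these few. Any claim that something is new, unique, unknown or untested is made for them only; others in the source may bear on it.

Two compounds share a core and a carbamate-bearing piperidine and have been tested in a functional assay on CHO-K1 cells with Glucose-dependent insulinotropic receptor (Homo sapiens) as the target, read by a luciferase reporter, with a stated time of 5 h; on this read-out higher numbers stand for larger maximal responses and lower numbers for smaller maximal responses. In this assay compound 1 `CC(C)OC(=O)N1CCC(Oc2ncnc3c2CCN3c2ccc(-c3nccs3)cc2F)CC1` gives 74%. Compound 2 `CC(C)OC(=O)N1CCC(Oc2ncnc3c2CCN3c2ccc(S(C)(=O)=O)cn2)CC1` carries a 5-(methylsulfonyl)pyridin-2-yl group on the nitrogen of the five-membered ring, and in this assay compound 2 reaches 111%. Among the two numbers known, compound 2 stands highest, and compound 1 lies lower by a gap that exceeds the usual scatter.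

Compound 3 `Cc1cc(S(C)(=O)=O)ccc1N1CCc2c(OC3CCN(C(=O)OC(C)C)CC3)ncnc21` has not yet been measured in this assay. It differs from compound 2 in one place: 2-methyl-4-(methylsulfonyl)phenyl in place of 5-(methylsulfonyl)pyridin-2-yl on a nitrogen on an aromatic ring in a ring. A six-membered aromatic ring of carbon only replaces a ring with one hetero atom, with one acceptor fewer and a methyl added.

Within the data shown here, no measured pair isolates this change, so the step cannot be read from the data. The author expects the step of a number 11 percentage points lower from compound 2 to compound 3 (beyond the scatter) to be small, more likely downward than upward, and probably within the scatter. For compound 3 the expected response in this assay is 100%, with a range from 75% to 120%.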

Compound 3, largest response reached (reported as percent of maximum), in percent of the reference or control that the assay uses: 80%
For compound 3 the middle estimate is 20 percentage points above the measured one; measured number inside the range.
By their numbers in this assay, from the lowest: compounds 1 and 3 (each within the scatter of the next); then compound 2.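

In this assay, the group on this nitrogen turns out to matter, with a number 31 percentage points lower from compound 2 to compound 3 (beyond the scatter) for this exchange. Among these compounds, until now no pair had given any step at this position, and this one shows that the maximal response changes with the aromatic group even though a methylsulfonyl group is kept on both sides. The step nevertheless joins two alterations, a six-membered aromatic ring of carbon only in place of a ring with one hetero atom and an added methyl, and no measurement at hand accounts for the loss or divides it between them.

As far as these compounds go, it remains open whether the phenyl group without the methyl, or the pyridinyl group with a methyl added, would stay with compound 2 or fall with compound 3. Also open, from the compounds shown here alone, is how the maximal response would change if a nitrile, a carboxylic acid or an amine took the place of the methylsulfonyl group on either ring.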